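A few compounds are considered here, and "the series" means these few. Any claim that something is new, unique, unknown or untested is made for them only; others in the source may bear on it.

Measured compounds in an assay on isolated protein for binding affinity to sphingosine 1-phosphate receptor 2 (Homo sapiens), read by surface plasmon resonance; on this read-out lower numbers stand for tighter binding and higher numbers for weaker binding:
compound 1 `CCCc1cc(NNC(=O)Nc2cc(Cl)nc(Cl)c2)nc2c1c(C)nn2C` — 2360 nM
compound 2 `Cn1ncc2c(-c3ccc(F)cc3)cc(NNC(=O)Nc3cc(Cl)nc(OCCF)c3)nc21` — 2790 nM
compound 3 `CCCc1cc(NNC(=O)Nc2cc(Cl)nc(Cl)c2)nc2c1cnn2C` — 1400 nM

Compound 1 sits second highest of the three numbers in this assay; compound 2 is nearest and compound 3 furthest, and both gaps are within the scatter, so the three compounds are not separated on these data.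

For the measured compounds named here, the only single-point step available, a 1.7-fold lower number from compound 1 to compound 3 (0.23 log units; within the scatter), concerns a different part of the shared core and says nothing about the change considered here.

Compound 4 `Cc1nn(C)c2nc(NNC(=O)Nc3cc(Cl)nc(Cl)c3)cc(-c3ccccc3)c12` differs from compound 1 by phenyl in place of propyl on an aromatic carbon. Going by the values given here, compound 2 also carries an aromatic ring of carbon where compound 1 carries propyl, but it differs from compound 1 in two further places, so no step is computed; its value and that of compound 1 lie within the scatter of each other. Nothing measured isolates the exchange of propyl for phenyl. Compound 4 is therefore expected to show a step of a 1.2-fold lower number from compound 1 to compound 4 (0.07 log units; within the scatter), not beyond the scatter. Compound 4 is estimated at 2000 nM, with a range from 700 nM to 6000 nM.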

Compound 4, dissociation constant: 5320 nM
For compound 4 the middle estimate is 2.7-fold (0.42 log units) below the measured one; the range from low to high includes it.
By their numbers in this assay, from the lowest: compounds 3, 1, 2 and 4 (each within the scatter of the next, the first and the last beyond it).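

In this assay, for the compounds shown here, the exchange of propyl for phenyl on the aromatic carbon opposite the ring nitrogen gives a 2.3-fold higher number from compound 1 to compound 4 (0.35 log units; beyond the scatter) and so, unlike the one earlier step elsewhere on the shared core, lies beyond the scatter. This position therefore responds to the exchange, with weaker binding for phenyl than for propyl, although the step is modest and rests on a single pair. Nothing measured alongside these compounds accounts for the step.

One pair cannot separate the effect of the aromatic ring from that of the larger group, and a cyclohexyl group or a longer chain such as pentyl at this position would distinguish the two readings. On these data alone, whether the exchange gives a similar step on the core of compound 3, with hydrogen in place of methyl, also stays open.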